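Removing the Bromo Group from Compound 1

The source may hold more compounds than are shown below. What is called first, only, known or untested is meant among the compounds shown, and "the series" means these compounds.

- compound 1 `COc1cccc(C(=O)Nc2nnc(/C=C/c3cc(OC)c(OC)c(OC)c3Br)s2)c1`: 60 nM
- compound 2 `COc1ccc(C(=O)Nc2nnc(/C=C/c3cc(OC)c(OC)c(OC)c3Br)s2)cc1`: 150 nM
- compound 3 `COc1cc(/C=C/c2nnc(NC(=O)c3ccc(Br)cc3)s2)c(Br)c(OC)c1OC`: 160 nM

In a functional assay on A549 cells (Homo sapiens) for antiproliferative activity, read by MTT assay, with a stated time of 48 h (a higher number here means a weaker inhibitor, a lower number a stronger inhibitor), compound 1 gives 60 nM, the lowest of the three numbers. The measured steps are a 2.5-fold higher number from compound 1 to compound 2 (0.40 log units; beyond the scatter) and a 2.7-fold higher number from compound 1 to compound 3 (0.43 log units; beyond the scatter), while a 1.1-fold higher number from compound 2 to compound 3 (0.03 log units; within the scatter) is the smallest. Compound 4 `COc1cccc(C(=O)Nc2nnc(/C=C/c3cc(OC)c(OC)c(OC)c3)s2)c1` differs from compound 1 at one place: hydrogen in place of bromo on an aromatic carbon. All three measured steps change the group on the carbonyl, so none of them tests the loss of bromo, and they serve only as a rough guide to size. A modest rise in this assay is expected, with a wide margin in either direction, as the other two compounds both lie above compound 1. The expected change is a 2.5-fold higher number from compound 1 to compound 4 (0.40 log units; beyond the scatter). For compound 4 the estimated value is 150 nM, with an expected range of 35 nM to 600 nM.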

Compound 4, half-maximal inhibitory concentration: 150 nM
The estimate for compound 4 equals the measured number at the digits printed; measured number inside the range.
By their numbers in this assay, from the lowest: compound 1; then compounds 2, 4 and 3 (each within the scatter of the next).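

For the compounds shown here, compound 4 gives the first direct reading of the bromo group on this aromatic carbon: in this assay, hydrogen in place of bromo produces a 2.5-fold higher number from compound 1 to compound 4 (0.40 log units; beyond the scatter). The step is modest, so the bromo adds to the activity of compound 1 but is not needed for compound 4 to remain active. Nothing shown here accounts for the size of this step. As far as these compounds go, whether chloro, methyl or an amine on this carbon would match the bromo remains open. So does whether removing the bromo costs the same with 4-methoxyphenyl or 4-bromophenyl on the carbonyl.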